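A few compounds are considered here, and "the series" means these few. Any claim that something is new, unique, unknown or untested is made for them only; others in the source may bear on it.

Compound 2, with the structure `CONC(=O)c1ccc(N(Cc2ccc(C3CCCCC3)cn2)C(=O)[C@H]2CCN2S(=O)(=O)c2c(F)c(F)c(F)c(F)c2F)cc1O`, is one of two compounds in this set that carry a number in a functional assay on MDA-MB-231 cells (Homo sapiens) for antiproliferative activity, with a stated time of 72 h; on this read-out lower numbers stand for an effect already at smaller amounts and higher numbers for an effect only at larger amounts of compound. In this assay compound 2 gives 6700 nM. Its companion compound 1, with the structure `O=C(NO)c1ccc(N(Cc2ccc(C3CCOCC3)cc2)C(=O)[C@H]2CCN2S(=O)(=O)c2c(F)c(F)c(F)c(F)c2F)cc1`, gives 4000 nM in this assay, and the two numbers lie within the usual scatter of repeated measurements, so neither can be placed ahead of the other. A third compound, compound 3 with the structure `O=C(NO)c1ccc(N(Cc2cnc(C3CCCCC3)cn2)C(=O)[C@H]2CCN2S(=O)(=O)c2c(F)c(F)c(F)c(F)c2F)c(F)c1`, has no number in this assay: for compound 3 the entry in this assay reads "not determined" (no result reported).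

Compound 4, with the structure `O=C1NCc2cc(N(Cc3ccc(C4CCCCC4)cn3)C(=O)[C@H]3CCN3S(=O)(=O)c3c(F)c(F)c(F)c(F)c3F)c(F)cc21`, has not been measured. It differs from compound 2 in one place: a group of 11 heavy atoms (8 carbon, 1 nitrogen, 1 oxygen, 1 fluorine; one five-membered non-aromatic ring with 1 hetero atom, one six-membered aromatic ring of carbon only) in place of a group of 12 heavy atoms (8 carbon, 1 nitrogen, 3 oxygen; one six-membered aromatic ring of carbon only), on an amide-type nitrogen. For the measured compounds named here, no pair of measured compounds shows what such an exchange does, so the direction of the step can only be estimated. The expectation is that the step from compound 2 to compound 4 stays small, a 1.3-fold higher number from compound 2 to compound 4 (0.13 log units; within the scatter), with a slight lean toward a larger amount being needed. For compound 4 the estimate in this assay is 9000 nM, within a range from 2500 nM to 30000 nM.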

Compound 4, half-maximal effective concentration: 2000 nM
Estimate against measurement, compound 4: 4.5-fold (0.65 log units) above; measured number below the stated range.
By their numbers in this assay, from the lowest: compounds 4, 1 and 2 (each within the scatter of the next, the first and the last beyond it).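

For the compounds shown here, the exchange on the amide-type nitrogen gives a 3.4-fold lower number from compound 2 to compound 4 (0.53 log units; beyond the scatter) in this assay, the first comparison here between compounds that differ in one place. It shows that this position responds to the group it carries: replacing 3-hydroxy-4-(methoxycarbamoyl)phenyl with a group holding a five-membered non-aromatic ring and a fluorine means that a smaller amount of compound is needed. No measurement offers an explanation for this step.

The five-membered non-aromatic ring and the fluorine enter together, along with the loss of the hydroxy and methoxycarbamoyl parts, so which of these changes accounts for the step remains open. Also open, as far as these compounds go, is how a group holding a carboxylic acid or an amine would behave in this same place.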